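A few compounds are considered here, and "the series" means these few. Any claim that something is new, unique, unknown or untested is made for them only; others in the source may bear on it.

Measured so far in an assay on HEK293 cells for inhibition of N-acylethanolamine-hydrolyzing acid amidase (Homo sapiens), read by fluorescence, with stated times of 10 min and 50 min; on this read-out higher numbers stand for weaker inhibition and lower numbers for stronger inhibition:
- compound 1 `CN1C[C@H](NC(=O)OCCCCC2CCCCC2)C1=O`: 1980 nM
- compound 2 `COC(=O)N1C[C@H](NC(=O)OCCCCC2CCCCC2)C1=O`: 7180 nM

Compound 2 gives the highest number of the two measured; its nearest neighbour is compound 1, and the step of a 3.6-fold higher number from compound 1 to compound 2 (0.56 log units; beyond the scatter) lies beyond the scatter.

Compound 3 `CON1C[C@H](NC(=O)OCCCCC2CCCCC2)C1=O` has not yet been tested in this assay. It differs from compound 2 in one place: methoxy in place of methoxycarbonyl on an amide-type nitrogen in a ring. The group that leaves sits on an amide-type nitrogen in a ring of a four-membered non-aromatic ring with 1 nitrogen, two ring bonds from the ring atom that bears a large group.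

Going by the values given here, no measured step covers methoxycarbonyl against methoxy directly. Among the compounds with values here, the only step on this nitrogen, a 3.6-fold higher number from compound 1 to compound 2 (0.56 log units; beyond the scatter), shows that replacing the small methyl by methoxycarbonyl raised the number modestly. Methoxy is again a small group with one acceptor, so a return toward the number of compound 1 is expected, with wide uncertainty.

Compound 3 is therefore estimated at 3000 nM in this assay, within 1000 nM to 10000 nM, a change of a 2.4-fold lower number from compound 2 to compound 3 (0.38 log units; beyond the scatter) that is expected rather than known.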

Compound 3, half-maximal inhibitory concentration: 16 nM
Compound 3: middle estimate off by 190-fold (2.27 log units), on the high side; measured number below the stated range.
By their numbers in this assay, from the lowest: compound 3; then compound 1; then compound 2.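

On the amide-type nitrogen in the four-membered non-aromatic ring, the earlier change from methyl to methoxycarbonyl gave only a modest shift of a 3.6-fold higher number from compound 1 to compound 2 (0.56 log units; beyond the scatter) in this assay, but this position can move the number much further: methoxy gives a 450-fold lower number from compound 2 to compound 3 (2.65 log units; beyond the scatter) and also a 120-fold lower number from compound 1 to compound 3 (2.09 log units; beyond the scatter) against the small methyl group. The numbers do not run with the size of the group, as methoxy gives the lowest number of the three, while methyl lies between methoxy and the larger methoxycarbonyl. Methyl and methoxy differ by the single oxygen on the ring nitrogen, so that atom accounts for the whole of the large step in this matched pair, although the measurements give no explanation for the effect.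

Ethoxy, benzyloxy or hydroxy on the same nitrogen would show whether the low number is specific to methoxy or extends to other groups attached through oxygen. From the compounds shown here alone, it also remains open whether the large step carries over when a shorter alkyl chain or a phenyl ring replaces the side chain shared by all three compounds.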